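The source may report more compounds than this note shows. Statements on the series, on what has been measured and on what is new or still open speak of the compounds shown alone.

Measured so far in a functional assay on EC9706 cells (Homo sapiens) for cytotoxicity, read by MTT assay, with a stated time of 72 h; on this read-out lower numbers stand for stronger inhibition and higher numbers for weaker inhibition:
compound 1, `NC(=O)N1CCN(C(=S)SCc2cn(Cc3ccccc3F)nn2)CC1`, gives 43100 nM;
compound 2, `CCNC(=O)N1CCN(C(=S)SCc2cn(Cc3ccccc3F)nn2)CC1`, gives 23700 nM.

Among the measured compounds shown here, compound 2 holds the lowest of the two numbers, but the only step, a 1.8-fold lower number from compound 1 to compound 2 (0.26 log units; within the scatter), lies within the scatter, so the two compounds cannot be ranked against each other. Compound 3, `CC(C)NC(=O)N1CCN(C(=S)SCc2cn(Cc3ccccc3F)nn2)CC1`, has not yet been measured. It differs from compound 2 by methyl in place of hydrogen on a saturated chain carbon bound to an amide-type nitrogen and a saturated chain carbon. For the measured compounds named here, the one measured step that bears on this change is a 1.8-fold lower number from compound 1 to compound 2 (0.26 log units; within the scatter), which put ethyl in place of hydrogen on the same amide-type nitrogen and stayed within the scatter. Growing that chain further is therefore expected to move this assay little, if at all, with no direction that the measured pair can support beyond the scatter. Compound 3 is expected to give 18000 nM, within a range of 8000 nM to 40000 nM. That estimate amounts to an expected step of a 1.3-fold lower number from compound 2 to compound 3 (0.12 log units; within the scatter).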

Compound 3, half-maximal inhibitory concentration: 20800 nM
Estimate against measurement, compound 3: 1.2-fold (0.06 log units) below; measured number inside the range.
By their numbers in this assay, from the lowest: compounds 3, 2 and 1 (each within the scatter of the next, the first and the last beyond it).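

In this assay, turning ethyl into isopropyl gives a 1.1-fold lower number from compound 2 to compound 3 (0.06 log units; within the scatter), so adding this methyl on the saturated chain carbon does not separate the two compounds. Among the compounds shown here, measured against the plain amide hydrogen, however, isopropyl gives a 2.1-fold lower number from compound 1 to compound 3 (0.32 log units; beyond the scatter), the first step on this amide-type nitrogen to pass beyond the scatter, although only modestly. Nothing measured here explains either step.

From the compounds shown here alone, whether a longer chain such as butyl, a ring such as cyclohexyl or phenyl, or a chain carrying an amine or a carboxylic acid on this nitrogen would extend that modest step remains open. The compounds shown also share the rest of the core, so they cannot show whether the same change would give a similar step on a different core.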